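A few compounds are considered here, and "the series" means these few. Any claim that something is new, unique, unknown or untested is made for them only; others in the source may bear on it.

Three compounds have been measured in a functional assay on Hs-578T cells (Homo sapiens) for cytotoxicity, read by sulforhodamine B assay, with a stated time of 48 h, tested at 0.01 uM; on this read-out lower numbers stand for a stronger effect and higher numbers for a weaker effect at the one concentration tested:

compound 1, `COc1cc(-c2cc(/C=C/C(=O)c3ccc(Cl)c(Cl)c3)[nH]n2)cc(OC)c1OC`, gives 98%
compound 2, `COc1ccc(-c2cc(/C=C/C(=O)c3cc(OC)c(OC)c(OC)c3)[nH]n2)cc1OC`, gives 95%
compound 3, `COc1cc(C(=O)/C=C/c2cc(-c3cc(OC)c(OC)c(OC)c3)n[nH]2)cc(OC)c1OC`, gives 93%

Compound 1 has the highest of the three numbers, but its gaps to compound 2 and to compound 3 both lie within the usual scatter, so none of the three can be set apart from the others on this read-out. Going by the values given here, the one step between compounds that differ in a single place, a number 2 percentage points lower from compound 2 to compound 3 (within the scatter), concerns a methoxy entering in place of a hydrogen on an aromatic carbon and also stays within the scatter.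

Compound 4, `COc1cc(-c2cc(/C=C/C(=O)c3ccc(F)c(F)c3)[nH]n2)cc(OC)c1OC`, is reached from compound 1 by one change: 3,4-difluorophenyl in place of 3,4-dichlorophenyl on a carbonyl carbon. The 3,4-dichlorophenyl leaves and a 3,4-difluorophenyl enters, on the carbonyl carbon whose other neighbour is a double-bonded chain carbon. Among the compounds with values here, no measured step touches an exchange of one halogen for another, so the step from compound 1 to compound 4 has no direct precedent here; the only guide is that all three measured numbers sit close together near the top of the scale. On that basis the expected step is a number 2 percentage points lower from compound 1 to compound 4 (within the scatter), that is, nothing beyond the scatter. Compound 4 is therefore estimated at 96%, within a range from 82% to 104%.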

Compound 4, a percentage reported as activity, at one concentration (the size of the read-out at that concentration, not a potency): 98%
For compound 4 the middle estimate is 2 percentage points below the measured one, within the range that was stated.
By their numbers in this assay, from the lowest: compounds 3, 2, 1 and 4 (each within the scatter of the next).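

In this assay, going by these compounds alone, placing 3,4-difluorophenyl instead of 3,4-dichlorophenyl on the carbonyl carbon gives no change at the digits printed from compound 1 to compound 4 (within the scatter), the first measured exchange of one halogen for another at this position. The two groups have the same number of heavy atoms and the same carbon-only aromatic ring, so the halogen is the only thing that differs, and at the one concentration tested the read-out does not tell chlorine and fluorine apart here. Nothing available explains this result, and a single pair cannot show whether the same would hold on another core.

Still open, on these data alone, is what a phenyl carrying an amine or a carboxylic acid would do on the same carbonyl carbon, since every group seen there so far is a phenyl bearing halogens or methoxy groups. Also open, as far as these compounds go, is whether compound 1 and compound 4 would still match at a concentration other than the one tested, since a comparison at a single concentration says nothing about potency.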